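Isobutyl in Place of Cyclobutyl on a Tolerated Compound

The source may hold more compounds than are shown below. What is called first, only, known or untested is meant among the compounds shown, and "the series" means these compounds.

In an ADME assay on Huh-7 cells (Homo sapiens) for cytotoxicity, with a stated time of 72 h (a lower number here means that less compound is tolerated, a higher number that more compound is tolerated), compound 1 `CC(C)CCn1nc(-c2cccs2)c(O)c(C2=NS(=O)(=O)c3cc(NS(=O)(=O)C4CC4)ccc3N2)c1=O` gives > 1000 nM as a limit of the assay and not a number. Compound 2 `CC(C)CCn1nc(CC2CCC2)c(O)c(C2=NS(=O)(=O)c3cc(NS(C)(=O)=O)ccc3N2)c1=O` stands at > 33000 nM as a limit too. Compound 3 `CC(C)CCc1nn(CCC(C)C)c(=O)c(C2=NS(=O)(=O)c3cc(NS(C)(=O)=O)ccc3N2)c1O` carries one change from compound 2, namely isobutyl in place of cyclobutyl on a saturated chain carbon bound to an aromatic carbon with isobutyl in place of cyclobutyl on a saturated chain carbon bound to an aromatic carbon. Going by the values given here, no measured pair shows this change, and no step beyond the usual scatter is expected for it in this assay here. The step expected is a step that the limit leaves unreadable from compound 2 to compound 3 and stays within that scatter. Compound 3 is estimated at 40000 nM with an expected range from 15000 nM to 100000 nM in this assay.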

Compound 3, half-maximal cytotoxic concentration: > 33000 nM
Compound 3 gave a limit, no number; the forecaster's own chance of this, stated with the estimate: 75%; the middle value is on the limit's open side.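

In this assay, compound 2 and compound 3 each give a limit and not a number, so no step between them can be read: the limit of > 33000 nM in this assay, at which 2 of the 3 values shown sit.

The compounds shown leave open whether isobutyl in place of cyclobutyl changes how much compound the cells tolerate.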